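The compounds below may be only part of what the source reports. "The series", "measured", "known", "first", "only" and "open" are said of these compounds alone.

Compound 1, `Cc1cc(Cl)ccc1-c1cccc(COc2ccc([C@H](CC(=O)O)c3nccn3C)cc2)c1C`, in an assay on CHO cells for agonist activity at Free fatty acid receptor 1 (Homo sapiens), read by luminescence, with a stated time of 20 s, in the presence of a further agent that is not named here; a higher number here means that more compound is needed for the effect, a lower number that less compound is needed: compound 1 gives 240 nM
Compound 2, `Cc1c(Cl)cccc1-c1cccc(COc2ccc([C@H](CC(=O)O)c3nccn3C)cc2)c1`: compound 2 gives 61 nM
Compound 3, `COc1ccccc1-c1cccc(COc2ccc([C@H](CC(=O)O)c3nccn3C)cc2)c1`: compound 3 gives 410 nM

Among these three, compound 3 gives the highest number, so of the three it needs the most compound to reach the effect. Its gap to compound 1 lies within the usual scatter, whereas the step of a 6.7-fold higher number from compound 2 to compound 3 (0.83 log units; beyond the scatter) lies beyond it. The unmeasured compound 4, `COc1ccc(-c2cccc(COc3ccc([C@H](CC(=O)O)c4nccn4C)cc3)c2)cc1`, differs from compound 3 in a single way: 4-methoxyphenyl in place of 2-methoxyphenyl on an aromatic carbon. Going by the values given here, no measured step covers such a move of the methoxy group from one place on the outer ring to another; the only step that touches this ring, a 6.7-fold higher number from compound 2 to compound 3 (0.83 log units; beyond the scatter), exchanges one set of groups for a different set and cannot separate the effect of where a group sits from the effect of which group it is. Without a comparable precedent, no shift beyond the scatter is expected. Compound 4 is estimated at 500 nM, with a range from 150 nM to 1600 nM. The expected step is a 1.2-fold higher number from compound 3 to compound 4 (0.09 log units; within the scatter), within the scatter.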

Compound 4, half-maximal effective concentration: 440 nM
The estimate for compound 4 lay 1.1-fold (0.06 log units) above the measured number; the measured number falls inside the stated range.
By their numbers in this assay, from the lowest: compound 2; then compounds 1, 3 and 4 (each within the scatter of the next).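

In this assay, changing 2-methoxyphenyl to 4-methoxyphenyl gives a 1.1-fold higher number from compound 3 to compound 4 (0.03 log units; within the scatter) and so shows that, on this outer ring, the place of the methoxy group has no effect that stands out from the scatter. The 3-chloro-2-methylphenyl ring of compound 2 stays apart from this second methoxy ring too, with a 7.2-fold higher number from compound 2 to compound 4 (0.86 log units; beyond the scatter) as the step, so neither methoxy ring shown matches compound 2. Nothing measured here offers an explanation for either step.

The compounds shown do not separate the parts played by the chlorine and the methyl group in compound 2. On these data alone, it also remains open whether a longer chain on the oxygen, such as ethoxy, or an amine on the outer ring would behave like methoxy.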